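Benzyl ring substituent swap on the thiazolidinedione series

The source may hold more compounds than are shown below. What is called first, only, known or untested is meant among the compounds shown, and "the series" means these compounds.

Three compounds of the shared core carry a measured number. Compound 1 `CC(C)(C)c1ccc(CN2C(=O)S/C(=C\c3ccc(N)cc3)C2=O)cc1` gives 80000 nM in a functional assay on FM3A cells (Mus musculus) for cytotoxicity, read by cell counting, with a stated time of 2 days; a higher number here means a weaker inhibitor, a lower number a stronger inhibitor. Compound 3 `Nc1ccc(/C=C2\SC(=O)N(Cc3ccc(Cl)cc3)C2=O)cc1` gives 60000 nM, and the step of a 1.3-fold lower number from compound 1 to compound 3 (0.12 log units; within the scatter) shows that swapping the substituent on the benzyl ring barely moves the number. Compound 2 `C=C(Br)C(=O)Nc1ccc(/C=C2\SC(=O)N(Cc3cccc(F)c3)C2=O)cc1` gives 4000 nM, the lowest number of the three; both compound 3 and compound 1 stand beyond the scatter above it, so compound 2 is the strongest inhibitor measured so far.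

Compound 4 `C=C(Br)C(=O)Nc1ccc(/C=C2\SC(=O)N(Cc3ccc(C)cc3)C2=O)cc1` is the next case. Its change from compound 2 is 4-methylphenyl in place of 3-fluorophenyl on a saturated chain carbon bound to an amide-type nitrogen in a ring. For the measured compounds named here, the only measured step touching the same part of the molecule is the one from compound 1 to compound 3, a substituent change on the same benzyl ring that stayed within the scatter. Going by the values given here, no measured pair separates a 3-fluorophenyl from a 4-methylphenyl directly, and compound 1 and compound 3 lack the bromoacrylamide of compound 2, so the comparison is indirect. The expectation is therefore a step of little or no size beyond the scatter, with no firm direction. Compound 4 is estimated at 4000 nM, between 1500 nM and 12000 nM, which means an expected step of no change at the digits printed from compound 2 to compound 4 (within the scatter).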

Compound 4, half-maximal inhibitory concentration: 6100 nM
For compound 4 the middle estimate is 1.5-fold (0.18 log units) below the measured one, within the range that was stated.
By their numbers in this assay, from the lowest: compounds 2 and 4 (each within the scatter of the next); then compounds 3 and 1 (each within the scatter of the next).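

In this assay, the change on the benzyl ring gives a 1.5-fold higher number from compound 2 to compound 4 (0.18 log units; within the scatter) in the presence of the bromoacrylamide, whereas the earlier step on this ring, a 1.3-fold lower number from compound 1 to compound 3 (0.12 log units; within the scatter), belonged to compounds with a plain amino group. The position therefore accepts 4-methylphenyl in place of 3-fluorophenyl without a change beyond the scatter, and the fluorine of compound 2 is not required to keep the number within the scatter of compound 4. No evidence on the cause of this result is available.

The step changes both the substituent and its place on the ring, so the contribution of each remains unresolved, and the listed compounds offer no pair that differs only by the bromoacrylamide. Also open, from the compounds shown here alone, is whether this tolerance on the benzyl ring extends to substituents of another kind, such as a carboxylic acid or a dimethylamino group, since the two readable steps cover only tert-butyl, chloro, fluoro and methyl.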